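This account rests on a few compounds, and the source may have more. Where it says the series, first, only, none or still open, it means among the compounds named here.

In a functional assay on MCF7 cells (Homo sapiens) for inhibition, read by MTT assay, with a stated time of 72 h (on this read-out lower numbers stand for stronger inhibition and higher numbers for weaker inhibition), compound 2 `CCN1C(=O)N(CC)C2C1N=C(SC)N2/N=C/C=C/c1ccccc1` gives 46600 nM, the highest of the two numbers recorded there, whereas compound 1 `CCN1C(=O)N(c2ccccc2)C2NC(=S)N(/N=C/C=C/c3ccccc3)C21` gives 2250 nM, a gap that lies beyond the scatter. Compound 3 `CCN1C(=O)N(CC)C2C1N=C(SC)N2/N=C/C=C/c1ccccc1[N+](=O)[O-]` differs from compound 2 by one change: nitro in place of hydrogen on an aromatic carbon, placed ortho to a large group. Within the data shown here, no measured pair isolates such a change, so the expected step of a 1.3-fold lower number from compound 2 to compound 3 (0.12 log units; within the scatter) is taken as small and toward a somewhat lower number, with wide uncertainty. Compound 3 is therefore estimated at 35000 nM, with a range from 10000 nM to 120000 nM.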

Compound 3, half-maximal inhibitory concentration: 66700 nM
Beside the measured number, compound 3's estimate is 1.9-fold (0.28 log units) below it; measured number inside the range.
By their numbers in this assay, from the lowest: compound 1; then compounds 2 and 3 (each within the scatter of the next).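

In this assay the change to nitro in place of hydrogen on an aromatic carbon, ortho to a large group, gives a 1.4-fold higher number from compound 2 to compound 3 (0.16 log units; within the scatter) and so stays within the scatter. Among these compounds, this is the first pair differing in one place, and it shows that this position on the phenyl ring accepts nitro with no readable shift in the number. Nothing at hand explains this result.

From the compounds shown here alone, whether an amine or a carboxylic acid at this position would move the number beyond the scatter stays open. Compound 1 and compound 2 differ in more than one place, so no single change can account for the gap between them.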